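The compounds below may be only part of what the source reports. "The series", "measured", "known", "first", "only" and "open" are said of these compounds alone.

Measured so far in this series:

compound 1, `COc1ccccc1/C=C/C(=O)OC/C=C/c1cc(OC)c(OC)cc1OC` — 100%
compound 2, `COc1cc(OC)c(OC)cc1/C=C/COC(=O)/C=C/c1ccccc1C(F)(F)F` — 100%
compound 3, `COc1cc(OC)c(OC)cc1/C=C/COC(=O)/C=C/c1ccc(OC)c(OC)c1OC` — 100%

All three readings come from a functional assay on the whole organism (strain Kunming) with Mus musculus as the target, with a stated time of 0.5 h, at a dose of 300 mg/kg by the intraperitoneal route; a higher number here means a weaker effect of the compound at the dose given, a lower number a stronger effect. In this assay compound 1 gives 100%, compound 2 gives 100% and compound 3 gives 100%. Compound 2 therefore stands level with compounds 1 and 3 at the digits recorded; its nearest neighbour is compound 1 and its furthest is compound 3, and neither gap reaches beyond the scatter of repeated measurements. Within the data shown here, only one pair in the set differs at a single place: no change at the digits printed from compound 1 to compound 2 (within the scatter), a step that is flat within the scatter.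

The next compound, compound 4, `COc1cc(OC)c(OC)cc1/C=C/COC(=O)/C=C/c1ccccc1Cl`, has not been measured. Compared with compound 2 the difference is chloro in place of trifluoromethyl on an aromatic carbon. Among the measured compounds shown here, the one measured step that bears on this position is the step from compound 1 to compound 2, which was flat, and every compound of the series so far sits at the same reading. The expectation for this assay is therefore no step beyond the scatter: no change at the digits printed from compound 2 to compound 4 (within the scatter) is what is estimated for the change from compound 2 to compound 4. For compound 4 the estimated reading is 100%, expected to lie between 88% and 100%.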

Compound 4, a percentage reported as activity, at one dose (the size of the read-out at that dose, not a potency): 100%
Compound 4: middle estimate and measured number agree at the digits printed; measured number inside the range.
By their numbers in this assay, from the lowest: compounds 1, 2, 3 and 4 (each within the scatter of the next).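

Working notes: in this assay this place on the aromatic ring now carries a third group, and replacing trifluoromethyl with chloro gives no change at the digits printed from compound 2 to compound 4 (within the scatter), while replacing methoxy with chloro gives no change at the digits printed from compound 1 to compound 4 (within the scatter). Going from four heavy atoms in the trifluoromethyl group to one in chloro, on an aromatic carbon ortho to a large group, leaves the reading flat, so methoxy, trifluoromethyl and chloro all read alike here, which the single earlier step could not show. Nothing measured alongside these readings bears on the result.

The compounds shown leave open whether an amine or a carboxylic acid at this place would move the reading away from the common level. Since all the compounds shown stand at the same reading, they also leave open which part of the structure, if any, the reading in this assay responds to.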